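Para-cyanophenyl sulfonamide on the cyclopropyl ketone core

This account rests on a few compounds, and the source may have more. Where it says the series, first, only, none or still open, it means among the compounds named here.

Compound 1, with the structure `O=C(c1ccc(OCCCN2CC[C@H](NS(=O)(=O)c3cccc(Cl)c3)C2)cc1)C1CC1`, gives 700 nM in an assay on isolated protein for binding affinity to histamine H2 receptor (Homo sapiens); on this read-out lower numbers stand for stronger inhibition and higher numbers for weaker inhibition. Among the three measured compounds, compound 1 stands second highest: compound 3, `O=C(c1ccc(OCCCN2CC[C@H](NS(=O)(=O)c3ccc(F)cc3)C2)cc1)C1CC1`, gives 500 nM, and the step of a 1.4-fold lower number from compound 1 to compound 3 (0.15 log units; within the scatter) lies within the scatter; compound 2, `Cc1ccccc1S(=O)(=O)N[C@H]1CCN(CCCOc2ccc(C(=O)C3CC3)cc2)C1`, gives 2200 nM, and the step of a 3.1-fold higher number from compound 1 to compound 2 (0.50 log units; beyond the scatter) lies beyond it.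

Compound 4, `N#Cc1ccc(S(=O)(=O)N[C@H]2CCN(CCCOc3ccc(C(=O)C4CC4)cc3)C2)cc1`, differs from compound 1 in one place: 4-cyanophenyl in place of 3-chlorophenyl on a sulfonyl sulfur. The measured steps that bear on this change are the swap to 4-fluorophenyl, a 1.4-fold lower number from compound 1 to compound 3 (0.15 log units; within the scatter), which changed little, and the swap to 2-methylphenyl, a 3.1-fold higher number from compound 1 to compound 2 (0.50 log units; beyond the scatter), which raised the number modestly. Among the compounds with values here, no measured step introduces a 4-cyanophenyl or a nitrile, so the expectation leans on the observation that another 4-substituted phenyl, in compound 3, stayed within the scatter of compound 1. Compound 4 is therefore expected to show a step of about a 1.1-fold lower number from compound 1 to compound 4 (0.03 log units; within the scatter) from compound 1, most likely within the scatter and in no firm direction. The estimated value for compound 4 is 650 nM, with a range from 200 nM to 2000 nM.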

Compound 4, inhibition constant: 1600 nM
Compound 4: middle estimate off by 2.5-fold (0.39 log units), on the low side; measured number inside the range.
By their numbers in this assay, from the lowest: compounds 3 and 1 (each within the scatter of the next); then compounds 4 and 2 (each within the scatter of the next).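

Compound 3 and compound 4 both carry a 4-substituted phenyl on the sulfonyl sulfur, yet in this assay they do not read alike: cyano in place of fluoro on an aromatic carbon gives a 3.2-fold higher number from compound 3 to compound 4 (0.51 log units; beyond the scatter) in this series. The closeness of compound 3 to compound 1 therefore does not extend to every 4-substituted phenyl, and the change to 4-cyanophenyl gives a 2.3-fold higher number from compound 1 to compound 4 (0.36 log units; beyond the scatter) as well. The step of a 1.4-fold lower number from compound 2 to compound 4 (0.14 log units; within the scatter) puts the 4-cyanophenyl and 2-methylphenyl sulfonamides together at the high-number end of the four compounds.

Nothing given here bears on why these groups differ. Going by these compounds, whether a methoxy group or an amine in place of the cyano would read like the fluoro or like the cyano remains open.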